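Aryloxy to benzamido swap on the pendant phenyl

This account rests on a few compounds, and the source may have more. Where it says the series, first, only, none or still open, it means among the compounds named here.

compound 1 `CN(C)C(=O)/C=C/c1ccc2noc(-c3ccccc3)c2c1`: > 100000 nM
compound 2 `O=C(O)c1ccc2noc(-c3ccc(Oc4ccccc4)cc3)c2c1`: 550 nM
compound 3 `O=C(O)c1ccc2noc(-c3ccc(Oc4ncc(Cl)cc4Cl)cc3)c2c1`: 2250 nM

In an assay for inhibition of inositol hexakisphosphate kinase 3 (Homo sapiens), read by colorimetric assay, coupled enzyme assay and malachite green, with a stated time of 120 min, in the presence of a further agent that is not named here (a higher number here means a weaker inhibitor, a lower number a stronger inhibitor), compound 2 gives 550 nM and compound 3 gives 2250 nM. Compound 1 reaches only a limit, > 100000 nM, (the limit of > 100000 nM in this assay, at which 1 of the 3 values shown sits), and so supplies no number. Among the two numbers compound 3 stands highest; its nearest neighbour is compound 2, and the single measured step, a 4.1-fold higher number from compound 2 to compound 3 (0.61 log units; beyond the scatter), separates the two.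

Compound 4 `O=C(O)c1ccc2noc(-c3ccc(NC(=O)c4ccccc4)cc3)c2c1` is the next member. Against compound 3 the change is benzamido in place of (3,5-dichloropyridin-2-yl)oxy on an aromatic carbon. Among the measured compounds shown here, the one measured step touches the same position, but it exchanged one aryl for another on an unchanged oxygen linker, and its size was modest. Here the linker itself is replaced, so no measured step speaks to the change directly; the shared core with a free carboxylic acid is kept, which in compound 2 and compound 3 went with numbers in the sub- to low-micromolar span.

The expectation is therefore a number within that span, with the direction against compound 3 uncertain and likely not beyond the scatter. Compound 4 is estimated at 1500 nM, range 300 nM to 8000 nM, meaning an expected 1.5-fold lower number from compound 3 to compound 4 (0.18 log units; within the scatter).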

Compound 4, half-maximal inhibitory concentration: 200 nM
The estimate for compound 4 lay 7.5-fold (0.88 log units) above the measured number, and the stated range ends above it.
By their numbers in this assay, from the lowest: compound 4; then compound 2; then compound 3. At a limit, above all of these: compound 1.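

The linker at this position carries more weight than the aryl swap on oxygen alone could show: in this assay there is an 11-fold lower number from compound 3 to compound 4 (1.05 log units; beyond the scatter), a large step that reverses the direction of the earlier change at this place. The comparison with the unsubstituted ring gives a 2.8-fold lower number from compound 2 to compound 4 (0.44 log units; beyond the scatter), so the lower number does not rest on the loss of the 3,5-dichloropyridin-2-yl group alone, since a plain phenyl ring ends both groups in that pair and the change there lies in the link to it. Compound 4 thus holds the lowest number among the measured compounds, and no measurement here ties either step to a particular feature of the swap.

Still open, going by these compounds, is whether the gain belongs to the amide as such, which a urea or sulfonamide linker, or a reversed amide, would test while the terminal phenyl stays in place. Also open, on these data alone, is how chloro or methoxy groups on the benzamido ring behave, and whether a methyl ester can stand in for the carboxylic acid with the benzamido group kept.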